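This account rests on a few compounds, and the source may have more. Where it says the series, first, only, none or still open, it means among the compounds named here.

Measured compounds:
Compound 1, `CCOc1ccc(-c2cccc(S(=O)(=O)NC)c2)cc1`: 200000 nM
Compound 2, `CCOc1ccc(-c2ccccc2)cc1`: > 200000 nM

Both compounds were tested in an assay on COS-7 cells for inhibition of patatin-like phospholipase domain-containing protein 2 (Mus musculus); on this read-out higher numbers stand for weaker inhibition and lower numbers for stronger inhibition. Compound 1 gives 200000 nM. For compound 2 the read-out is a limit rather than a number, > 200000 nM, so compound 2 stands at the edge of what this assay can report. Among the compounds with values here, the single measured step, a number no lower from compound 1 to compound 2 (the limit leaves the size open), therefore has no readable size, because one of its two ends sits at the limit of > 200000 nM in this assay, at which 1 of the 2 values shown sits.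

Compound 3, `CCOc1ccc(-c2cccc(C)c2)cc1`, is the compound still to be measured. It differs from compound 2 as follows: methyl in place of hydrogen on an aromatic carbon. Within the data shown here, no measured step shows what a methyl in place of hydrogen does, so the measured data give neither a direction nor a size for this change. Compound 3 is expected to give about 200000 nM, within a range from 60000 nM to 500000 nM. The step of a number no higher from compound 2 to compound 3 (the limit leaves the size open) is thus estimated to stay within the usual scatter.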

Compound 3, half-maximal inhibitory concentration: 70000 nM
Compound 3: the middle estimate sits 2.9-fold (0.46 log units) above what was measured, within the range that was stated.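

At this aromatic carbon, methyl in place of hydrogen gives an at least 2.8-fold lower number from compound 2 to compound 3 (0.45 log units; beyond the scatter) in this assay, so a single added carbon already changes the read-out by more than the usual scatter. Methyl in place of methylsulfamoyl on the same carbon gives a 2.9-fold lower number from compound 1 to compound 3 (0.46 log units; beyond the scatter), which shows that in this pair the smaller group goes with the stronger inhibition, and that the methylsulfamoyl group is not needed to reach this level. The read-out of compound 2 is a limit and not a number, so the step from hydrogen to methyl has no exact size: the limit of > 200000 nM in this assay, at which 1 of the 3 values shown sits.

Going by these compounds, whether an ethyl group, a longer chain or an amine on this carbon would strengthen inhibition further remains open. Also open, on these data alone, is whether a methyl on another carbon of this ring would produce a similar step.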